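The compounds below may be only part of what the source reports. "The series", "measured", "known", "first", "only" and "open" are said of these compounds alone.

Compound 1 `CCN(CCCn1sc2cc(OC)c(OC)cc2c1=O)Cc1ccccc1` gives 46.3% in an assay on isolated protein for inhibition of Amine oxidase [flavin-containing] B (Homo sapiens), read by fluorescence, with a stated time of 30 min, tested at 10 uM; on this read-out higher numbers stand for more inhibition at the one concentration tested (going by the name of the read-out) and lower numbers for less inhibition.
Compound 2 `CCN(CCCn1sc2cc(OC)c(OC)cc2c1=O)Cc1ccccc1OC` gives 37% in this assay.
Compound 3 `CCN(CCCn1sc2cc(OC)c(OC)cc2c1=O)Cc1ccccc1N(C)C` gives 45.4% in this assay.

All three numbers lie within the usual scatter of one another. Compound 3 sits closest to compound 1, the step being a number 0.9 percentage points lower from compound 1 to compound 3 (within the scatter); the step of a number 8.4 percentage points higher from compound 2 to compound 3 (within the scatter) is the largest involving compound 3, and it too stays within the scatter.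

Compound 4 `CCN(CCCn1sc2cc(OC)c(OC)cc2c1=O)Cc1ccc(N(C)C)cc1` is not yet measured. It differs from compound 3 by 4-(dimethylamino)phenyl in place of 2-(dimethylamino)phenyl on a saturated chain carbon bound to an amine nitrogen. Going by the values given here, no measured step moves the dimethylamino group around the benzyl ring, so the only steps that bear on it are those that put a substituent onto that ring at all: a number 9.3 percentage points lower from compound 1 to compound 2 (within the scatter) and a number 0.9 percentage points lower from compound 1 to compound 3 (within the scatter), neither beyond the scatter. On that basis no step beyond the scatter is expected in this assay for compound 4, in either direction.

Compound 4 is therefore estimated at 45% in this assay, within 30% to 60%. The expected step is a number 0.4 percentage points lower from compound 3 to compound 4 (within the scatter).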

Compound 4, a percentage reported as inhibition, at one concentration (the size of the read-out at that concentration, not a potency): 40.1%
The estimate for compound 4 lay 4.9 percentage points above the measured number; measured number inside the range.
By their numbers in this assay, from the lowest: compounds 2, 4, 3 and 1 (each within the scatter of the next).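

Moving the group from 2-(dimethylamino)benzyl to 4-(dimethylamino)benzyl gives a number 5.3 percentage points lower from compound 3 to compound 4 (within the scatter) in this assay and is the first reading of where dimethylamino sits on this ring, and the two placements are not told apart. Dimethylamino in place of hydrogen gives a number 6.2 percentage points lower from compound 1 to compound 4 (within the scatter) and the swap from 2-methoxyphenyl to 4-(dimethylamino)phenyl gives a number 3.1 percentage points higher from compound 2 to compound 4 (within the scatter), so no change at this benzyl ring has yet moved the number beyond the scatter. No measurement at hand bears on the reasons for these numbers.

Open, going by these compounds, is whether a carboxylic acid or a nitrile on the benzyl ring would give a step beyond the scatter. Also open, on these data alone, is whether a longer chain between the amine nitrogen and the shared core would do so.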